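Replacing the hydroxymethyl group of compound 2 with hydrogen

A few compounds are considered here, and "the series" means these few. Any claim that something is new, unique, unknown or untested is made for them only; others in the source may bear on it.

In an ADME assay on L1210 cells (Mus musculus) for cytotoxicity, with a stated time of 48 h (a higher number here means a weaker inhibitor, a lower number a stronger inhibitor), compound 2 (`C=C1[C@H](C)CCC[C@]1(C)CC/C(C)=C/CC1=C(O)C(=O)C=C(N[C@H](CO)C(=O)O)C1=O`) gives 2.6 ug/mL. Compound 1 (`C=C1[C@H](C)CCC[C@]1(C)CC/C(C)=C/CC1=C(O)C(=O)C=C(N[C@@H](C(=O)O)C(C)C)C1=O`) gives 3.4 ug/mL. The comparison between these two is a 1.3-fold lower number from compound 1 to compound 2 (0.12 log units; within the scatter), so compound 2 stands level with compound 1 on these numbers. Compound 3 (`CC1=CCC[C@](C)(CC/C(C)=C/CC2=C(O)C(=O)C=C(N[C@@H](CO)C(=O)O)C2=O)[C@@H]1C`) gives no number, only a limit of the assay, > 10 ug/mL.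

The next compound to be measured is compound 4 (`C=C1[C@H](C)CCC[C@]1(C)CC/C(C)=C/CC1=C(O)C(=O)C=C(NCC(=O)O)C1=O`). Its difference from compound 2 is hydrogen in place of hydroxymethyl on a saturated chain carbon bound to an amine nitrogen and a carbonyl carbon, so that (1-carboxy-2-hydroxyethyl)amino becomes (carboxymethyl)amino.

Within the data shown here, only one measured step bears on this change, and it was made at the same place. Hydroxymethyl in place of isopropyl gave a 1.3-fold lower number from compound 1 to compound 2 (0.12 log units; within the scatter). Among the measured compounds shown here, that step shows little response in this assay to the group carried there, although no compound with hydrogen at this place has yet been measured. On the evidence of that single step, no change beyond the scatter is expected, and no direction can be favoured with confidence. The expected step is a 1.2-fold higher number from compound 2 to compound 4 (0.06 log units; within the scatter). For compound 4 the estimated value is 3 ug/mL, with an expected range from 1.3 ug/mL to 7.5 ug/mL.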

Compound 4, half-maximal inhibitory concentration: 4 ug/mL
The estimate for compound 4 lay 1.3-fold (0.12 log units) below the measured number, and the stated range covers the measured number.
By their numbers in this assay, from the lowest: compounds 2, 1 and 4 (each within the scatter of the next). At a limit, above all of these: compound 3.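

Compound 4 carries only hydrogen on the saturated chain carbon bound to an amine nitrogen and a carbonyl carbon, so the response at this place can now be read without any group there; in this assay losing the hydroxymethyl group gave a 1.5-fold higher number from compound 2 to compound 4 (0.19 log units; within the scatter) and nothing larger. Hydrogen in place of isopropyl gave a 1.2-fold higher number from compound 1 to compound 4 (0.07 log units; within the scatter) as well, so the little response first seen between two substituted compounds now extends to the unsubstituted carbon, and hydroxymethyl, isopropyl and hydrogen all stand level in compounds 1, 2 and 4. Nothing measured here gives a reason for this level response.

As far as these compounds go, whether a longer chain, a phenyl ring or an amine on this carbon would also leave the number level stays open, since the three groups compared cover only a narrow range of what could stand there. Also open, from the compounds shown here alone, is what happens when the carboxylic acid, which compounds 1, 2 and 4 all retain, gives way to an amide or an ester.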